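The source may hold more compounds than are shown below. What is called first, only, known or untested is meant among the compounds shown, and "the series" means these compounds.

Measured compounds in a functional assay on MCF7 cells (Homo sapiens) for cytotoxicity, read by MTT assay, with a stated time of 48 h; on this read-out higher numbers stand for weaker inhibition and lower numbers for stronger inhibition:
compound 1 `C=CC(=C)CC[C@@H]1[C@@]2(C)CCC[C@](C)(COC(=O)/C=C\c3ccc(O)cc3)[C@@H]2CC[C@@]1(C)O` gives 15100 nM
compound 2 `C=CC(=C)CC[C@@H]1[C@@]2(C)CCC[C@](C)(COC(=O)/C=C/c3ccc(O)cc3)[C@@H]2CC[C@@]1(C)O` gives 16600 nM
compound 3 `C=C1CC[C@@H]2[C@](C)(CCC[C@]2(C)C(=O)O)[C@H]1CC/C(C)=C/CO` gives > 40000 nM

Compound 3 stands apart from the two numbers: the entry for compound 3, > 40000 nM, is a limit of this assay, not a measured number, as noted under (the limit of > 40000 nM in this assay, at which 1 of the 3 values shown sits). Compounds 1 and 2 both lie within the measured range; the step of a 1.1-fold higher number from compound 1 to compound 2 (0.04 log units; within the scatter) is within the scatter, and the two differ only in configuration as drawn (the fact that compounds 1 and 2 differ only in the configuration as drawn).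

The next compound is compound 4 `C=C[C@@]1(C)O[C@H]1C[C@H]1C(=C)CC[C@@H]2[C@]1(C)CCC[C@]2(C)C(=O)O`. Change from compound 3 to compound 4:
a group of 6 heavy atoms (5 carbon, 1 oxygen; one three-membered non-aromatic ring with 1 hetero atom) in place of a group of 6 heavy atoms (5 carbon, 1 oxygen; no ring), on a saturated chain carbon bound to a saturated ring carbon

Going by the values given here, no measured step bears on this exchange: the only step available, a 1.1-fold higher number from compound 1 to compound 2 (0.04 log units; within the scatter), concerns a drawn double-bond configuration on a different scaffold and gives no guidance on a ring-for-chain swap of this kind. The expectation for compound 4 therefore rests on compound 3 alone, which sits at the limit, so no directional step beyond the scatter is anticipated and a limit result remains likely.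

Compound 4 is estimated at 40000 nM, with a range from 15000 nM to 100000 nM. This estimate corresponds to an expected step of a number no higher from compound 3 to compound 4 (the limit leaves the size open).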

Compound 4, half-maximal inhibitory concentration: > 40000 nM
Compound 4: only a limit was reported (the forecaster's own chance of this, stated with the estimate: 55%); the middle value sits exactly at the limit.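

In this assay, no step can be read from compound 3 to compound 4, since both entries are limits: the limit of > 40000 nM in this assay, at which 2 of the 4 values shown sit.
The compounds shown leave open whether a three-membered ring group in place of 4-hydroxy-2-methylbut-2-en-1-yl changes the read-out at all.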